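Shifting the Pyridine Nitrogen and Adding Fluorine

The source may hold more compounds than are shown below. What is called first, only, known or untested is meant among the compounds shown, and "the series" means these compounds.

Three compounds share a core and differ in the aromatic group attached to the far ring. Compound 1 `CCC(C)(C)Cc1c[nH]c(CCc2ccc(-c3ccncc3)cc2)n1` carries a pyridin-4-yl group and, in a functional assay on HEK293 cells for agonist activity at Bombesin receptor subtype-3 (Homo sapiens), read by luminescence and calcium flux, with a stated time of 10 min (on this read-out higher numbers stand for an effect only at larger amounts of compound and lower numbers for an effect already at smaller amounts), compound 1 gives 95 nM. Compound 2 `CCC(C)(C)Cc1c[nH]c(CCc2ccc(-c3cccnc3)cc2)n1` carries a pyridin-3-yl group instead; in this assay compound 2 gives 98 nM. Compound 3 `O=C(O)c1cc(F)c(F)cc1-c1ccc(CCc2nc(CC3CCCCC3)c[nH]2)cc1` has a quite different aryl group and in this assay compound 3 gives 103 nM. Compound 2 stands in the middle of these three numbers, and all three lie within the usual scatter of one another.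

The only measured step among these compounds is a 1.0-fold higher number from compound 1 to compound 2 (0.01 log units; within the scatter), which shows that moving the ring nitrogen from one position to another left the read-out unchanged within scatter.

Compound 4 `CCC(C)(C)Cc1c[nH]c(CCc2ccc(-c3ccc(F)cn3)cc2)n1` is the unmeasured analogue, with 5-fluoropyridin-2-yl in place of pyridin-3-yl on an aromatic carbon. Going by the values given here, the ring nitrogen again moves, and a fluorine is added; the data hold no measured step for an added fluorine at this group. Among the compounds with values here, since the one relevant step, a 1.0-fold higher number from compound 1 to compound 2 (0.01 log units; within the scatter), stayed within the scatter, a step within the scatter is expected from compound 2 to compound 4 as well, namely a 1.0-fold higher number from compound 2 to compound 4 (0.01 log units; within the scatter). Compound 4 is therefore estimated at 100 nM in this assay, within a range of 40 nM to 250 nM.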

Compound 4, half-maximal effective concentration: 97 nM
Estimate against measurement, compound 4: 1.0-fold (0.01 log units) above, within the range that was stated.
By their numbers in this assay, from the lowest: compounds 1, 4, 2 and 3 (each within the scatter of the next).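

In this assay, 5-fluoropyridin-2-yl in place of pyridin-3-yl gives a 1.0-fold lower number from compound 2 to compound 4 (0.00 log units; within the scatter), and the same group in place of pyridin-4-yl gives a 1.0-fold higher number from compound 1 to compound 4 (0.01 log units; within the scatter). The earlier step covered only a shift of the ring nitrogen between two unsubstituted pyridines, whereas these steps show that, at this aromatic carbon para to a large group, a third nitrogen placement combined with a fluorine on the ring also cannot be told apart from either of them on this read-out. No separate evidence is available to explain why these groups give such closely matched numbers.

As far as these compounds go, because the nitrogen placement and the fluorine enter together in compound 4, the effect of each alone stays unknown, and unsubstituted pyridin-2-yl would be needed to separate them. From the compounds shown here alone, all three groups compared here are six-membered aromatic rings with one hetero atom, so it also remains open whether the same position would give a similar number with a non-aromatic group, such as an amine or a longer alkyl chain.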